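Tert-butyl for methoxy on compound 1

The compounds below may be only part of what the source reports. "The series", "measured", "known", "first", "only" and "open" are said of these compounds alone.

Compound 1 (`COc1ccc(/C=C2\CN(C)C/C(=C\c3ccccc3F)C2=O)cc1`) gives 22100 nM in an ADME assay on L02 cells (Homo sapiens) for cytotoxicity, read by MTT assay, with a stated time of 24 h (on this read-out higher numbers stand for weaker inhibition and lower numbers for stronger inhibition), and stands at the high end of the numbers, within the scatter of compound 3 (`COc1cc(/C=C2\CN(C)C/C(=C\c3ccccc3F)C2=O)cc(OC)c1`), which gives 11900 nM in this assay. Compound 2 (`COc1ccc(/C=C2\CN(C)C/C(=C\c3ccccc3F)C2=O)cc1OC`) gives 10500 nM in the same read-out. Among the measured compounds shown here, the only measured single-place step (a 2.1-fold lower number from compound 1 to compound 2 (0.32 log units; beyond the scatter)) is modest and lies just beyond the scatter, for methoxy in place of hydrogen on an aromatic carbon.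

Compound 4 (`CN1C/C(=C\c2ccc(C(C)(C)C)cc2)C(=O)/C(=C/c2ccccc2F)C1`) is reached through tert-butyl in place of methoxy on an aromatic carbon as tert-butyl in place of methoxy on an aromatic carbon, para to a large group. For the measured compounds named here, no measured step removes that methoxy or introduces tert-butyl, so the step from compound 1 to compound 2 bears on it only loosely. On that modest step (a 2.1-fold lower number from compound 1 to compound 2 (0.32 log units; beyond the scatter)), a small shift to a lower number is expected, probably within the scatter. The expected step is (a 1.4-fold lower number from compound 1 to compound 4 (0.14 log units; within the scatter)). For compound 4 the estimated value is 16000 nM (estimated range 7500 nM to 33000 nM).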

Compound 4, half-maximal inhibitory concentration: 25800 nM
For compound 4 the middle estimate is 1.6-fold (0.21 log units) below the measured one; the range from low to high includes it.
By their numbers in this assay, from the lowest: compounds 2, 3, 1 and 4 (each within the scatter of the next, the first and the last beyond it).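

In this assay, tert-butyl in place of methoxy on the aromatic carbon para to a large group gives a 1.2-fold higher number from compound 1 to compound 4 (0.07 log units; within the scatter), so compound 1 and compound 4 cannot be told apart on this read-out. Among the compounds shown here, the only earlier single-place step added a methoxy group, whereas this one replaces the methoxy group at this position and shows that tert-butyl, with no hydrogen-bond acceptor, can stand there without a step beyond the scatter. Nothing at hand offers an explanation for this result.

Open, from the compounds shown here alone, is whether a carboxylic acid or a dimethylamino group on this aromatic carbon would also stay within the scatter of compound 1. Also open, going by these compounds, is whether the step of a 2.1-fold lower number from compound 1 to compound 2 (0.32 log units; beyond the scatter) would carry over to the tert-butyl compound.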